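Replacing the benzothiazole amide with a benzoyl hydrazide

The source may report more compounds than this note shows. Statements on the series, on what has been measured and on what is new or still open speak of the compounds shown alone.

Measured compounds:
compound 1 `CCOC(=O)C1=C(C)NC(C)=C(C(=O)OCC)C1c1ccc(OCC(=O)Nc2c(C)cccc2C)cc1`: 15.9%
compound 2 `CCOC(=O)C1=C(C)NC(C)=C(C(=O)OCC)C1c1ccc(OCC(=O)Nc2ccc(C)cc2)cc1`: 43.9%
compound 3 `CCOC(=O)C1=C(C)NC(C)=C(C(=O)OCC)C1c1ccc(OCC(=O)Nc2nc3ccccc3s2)cc1`: 47.7%

In a functional assay on the whole organism (strain Wistar) for inhibition, with Rattus norvegicus as the target, read by paw edema, with stated times of 30 min and 0.5 h, at a dose of 20 mg/kg (on this read-out higher numbers stand for more inhibition at the one dose given (going by the name of the read-out) and lower numbers for less inhibition), compound 3 gives the highest of the three numbers. The step of a number 3.8 percentage points higher from compound 2 to compound 3 (within the scatter) stays within the scatter, whereas a number 31.8 percentage points higher from compound 1 to compound 3 (beyond the scatter) lies beyond it, so compound 3 and compound 2 cannot be told apart, while both stand clearly above compound 1.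

Compound 4 `CCOC(=O)C1=C(C)NC(C)=C(C(=O)OCC)C1c1ccc(OCC(=O)NNC(=O)c2ccccc2)cc1` differs from compound 3 by benzamido in place of 1,3-benzothiazol-2-yl on an amide-type nitrogen. Both measured steps into compound 3 exchange one aryl group for another on this same nitrogen; none of them brings in a benzamido group, so they give only loose guidance and no direction can be expected with confidence. Compound 4 is therefore estimated at 38%, with a range from 18% to 56%. The expected step is a number 9.7 percentage points lower from compound 3 to compound 4 (within the scatter), within the scatter.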

Compound 4, a percentage reported as inhibition, in the whole organism at one dose (the size of the read-out at that dose, not a potency): 9.1%
Beside the measured number, compound 4's estimate is 28.9 percentage points above it; the whole stated range lies above it.
By their numbers in this assay, from the lowest: compounds 4 and 1 (each within the scatter of the next); then compounds 2 and 3 (each within the scatter of the next).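

In this assay, a benzamido group on this amide-type nitrogen gives a clear loss, with a number 38.6 percentage points lower from compound 3 to compound 4 (beyond the scatter) and a number 34.8 percentage points lower from compound 2 to compound 4 (beyond the scatter). With a number 6.8 percentage points lower from compound 1 to compound 4 (within the scatter), the two cannot be told apart, so a quite different group on this nitrogen sits at the same low level as 2,6-dimethylphenyl. Nothing available accounts for this loss. Going by these compounds, what stays open is whether an acetamido group or a benzyl group on this nitrogen would stay at that low level or reach the level of compound 2 and compound 3.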